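This account rests on a few compounds, and the source may have more. Where it says the series, first, only, none or still open, it means among the compounds named here.

Three compounds share one core, each carrying an acrylamide on a phenyl group attached to a chlorinated ring, with an amide at the far end that varies. Compound 1 `C=CC(=O)Nc1ccc(-c2nc(Cl)cc(Nc3ccc(C(=O)Nc4ccc(OC)cc4)cc3)n2)cc1` has "not determined" (no result reported) in a functional assay on HL-60 cells (Homo sapiens) for antiproliferative activity, read by MTT assay, with a stated time of 48 h; a higher number here means a weaker inhibitor, a lower number a stronger inhibitor. Compound 2 `C=CC(=O)Nc1ccc(-c2nc(Cl)cc(Nc3ccc(C(=O)Nc4cccc(C)c4)cc3)n2)cc1` gives 3660 nM in this assay, and compound 3 `C=CC(=O)Nc1ccc(-c2nc(Cl)cc(Nc3ccc(C(=O)Nc4cc(C(F)(F)F)cc(C(F)(F)F)c4)cc3)n2)cc1` gives 4790 nM; these two numbers lie within the usual scatter of each other, so neither compound stands apart as the stronger inhibitor. Compound 4 `C=CC(=O)Nc1ccc(-c2nc(Cl)cc(Nc3ccc(C(=O)N(C)C)cc3)n2)cc1` differs from compound 2 by dimethylamino in place of (3-methylphenyl)amino on a carbonyl carbon. For the measured compounds named here, no measured pair shows what such a change does here, so the expectation rests only on the weak numbers seen so far. The estimated step from compound 2 to compound 4 is a 1.8-fold higher number from compound 2 to compound 4 (0.25 log units; within the scatter), toward a weaker compound. Compound 4 is expected to give about 6500 nM, with a range of 2000 nM to 22000 nM.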

Compound 4, half-maximal inhibitory concentration: > 50000 nM
Compound 4 gave a limit, no number (the forecaster's own chance of this, stated with the estimate: 20%); at least 7.6-fold (0.88 log units) between middle value and limit.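

Until now, the far end of the molecule had only carried aryl amides, so nothing showed how much this position could matter. Compound 4 gives only a limit, > 50000 nM, in this assay, not a number. Dimethylamino in place of (3-methylphenyl)amino on the carbonyl carbon means an at least 13-fold higher number from compound 2 to compound 4 (1.13 log units; beyond the scatter), so this position is clearly sensitive to the change, which removes the aromatic ring and the amide hydrogen together.

Which of these two losses counts remains open. A methylamino group on the same carbonyl carbon, keeping that hydrogen without a ring, would help to separate them.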